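Oxan-4-yl in place of oxetan-3-yl: notes on compound 3

The source may report more compounds than this note shows. Statements on the series, on what has been measured and on what is new or still open speak of the compounds shown alone.

Measured in a functional assay on HT-29 cells (Homo sapiens) for inhibition, read by luminescence and CellTiter-Glo, with a stated time of 24 h; on this read-out lower numbers stand for an effect already at smaller amounts and higher numbers for an effect only at larger amounts of compound:
- compound 1 `CC(C)Cn1nc(C(=O)N[C@H]2COc3ccccc3N(C)C2=S)nc1Cc1ccccc1` gives 1230 nM
- compound 2 `CN1C(=S)[C@@H](NC(=O)c2nc(Cc3ccccc3)n(CC3COC3)n2)COc2ccccc21` gives 2830 nM

Of the two numbers in this assay, compound 2 holds the higher, 2830 nM. Compound 3 `CN1C(=S)[C@@H](NC(=O)c2nc(Cc3ccccc3)n(CC3CCOCC3)n2)COc2ccccc21` is still to be measured. It has oxan-4-yl in place of oxetan-3-yl on a saturated chain carbon bound to an aromatic nitrogen.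

For the measured compounds named here, only one measured step bears on this change: a 2.3-fold higher number from compound 1 to compound 2 (0.36 log units; beyond the scatter). It sits at the same place and is modest, but it is a different exchange, with oxetan-3-yl in place of isopropyl. Going by the values given here, no measured compound carries oxan-4-yl, so the data favour no clear direction, and a single step gives only a rough guide to size. The expected step is a 1.1-fold lower number from compound 2 to compound 3 (0.05 log units; within the scatter), which amounts to no expected change beyond the scatter. For compound 3 the estimated value is 2500 nM, with an expected range of 1000 nM to 6000 nM.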

Compound 3, half-maximal effective concentration: 6310 nM
Compound 3: middle estimate off by 2.5-fold (0.40 log units), on the low side; measured number outside the range, above it.
By their numbers in this assay, from the lowest: compound 1; then compound 2; then compound 3.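

In this assay, the position on a saturated chain carbon bound to an aromatic nitrogen responds to ring size as well as to the change from isopropyl: oxan-4-yl in place of oxetan-3-yl gives a 2.2-fold higher number from compound 2 to compound 3 (0.35 log units; beyond the scatter), although the two groups match in hydrogen-bond donors and acceptors as counted. Oxan-4-yl in place of isopropyl gives a 5.1-fold higher number from compound 1 to compound 3 (0.71 log units; beyond the scatter), the largest step in the set, so the three compounds rank in the order isopropyl, oxetan-3-yl, oxan-4-yl, with none going against that order and each step beyond the scatter. No measurement at hand accounts for these steps.

With only two oxygen-bearing rings and one branched alkyl group at this place, the compounds shown do not separate the effect of ring size from that of the ring oxygen, which a cyclohexyl group would address directly. From the compounds shown here alone, it also remains open whether an amine, a carboxylic acid or a shorter chain here would bring the number below that of compound 1 1230 nM or continue the rise seen so far.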